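The compounds below may be only part of what the source reports. "The series", "measured", "known", "first", "only" and "open" are said of these compounds alone.

Of the compounds shown here, two with a shared core have been tested in a functional assay on OVCAR-3 cells (Homo sapiens) for inhibition, read by sulforhodamine B assay, with a stated time of 48 h, tested at 10 uM; on this read-out higher numbers stand for more inhibition at the one concentration tested (going by the name of the read-out) and lower numbers for less inhibition. Compound 1, `c1ccc(-c2cn3ccnc3c(-c3ccc4ncn(C5CCCCC5)c4c3)n2)cc1`, gives 41.8% in this assay. Compound 2, `CCc1ccc(-c2cn3ccnc3c(-c3ccc4ncn(Cc5ccccc5)c4c3)n2)cc1`, gives 31.2% in this assay, the lower of the two numbers, and the gap to compound 1 lies beyond the usual scatter. Compound 3, `c1ccc(Cn2cnc3ccc(-c4nc(-c5cccc6ccccc56)cn5ccnc45)cc32)cc1`, is not yet measured; it differs from compound 2 by naphthalen-1-yl in place of 4-ethylphenyl on an aromatic carbon. For the measured compounds named here, no measured pair shows what such a change does, so a step from compound 2 to compound 3 of about a number 3.8 percentage points higher from compound 2 to compound 3 (within the scatter) is expected, within the scatter in either direction. For compound 3 an inhibition of 35% is estimated, between 15% and 55%.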

Compound 3, a percentage reported as inhibition, at one concentration (the size of the read-out at that concentration, not a potency): 1.44%
Beside the measured number, compound 3's estimate is 33.6 percentage points above it; measured number below the stated range.
By their numbers in this assay, from the lowest: compound 3; then compound 2; then compound 1.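

Putting naphthalen-1-yl in place of 4-ethylphenyl on this aromatic carbon, next to the ring nitrogen, gives this assay a number 29.8 percentage points lower from compound 2 to compound 3 (beyond the scatter). So the group at this position can strongly change the read-out, even though both groups are carbon-only aromatic rings with no net charge. Nothing measured here bears on the reason for this loss.

The compounds shown leave open whether naphthalen-2-yl would behave the same way. They also leave open how an amine or a carboxylic acid in place of the ethyl on the phenyl ring would read.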